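Adding a bromo substituent to the benzoate part of compound 3

The source may hold more compounds than are shown below. What is called first, only, known or untested is meant among the compounds shown, and "the series" means these compounds.

Compound 3 `COC(=O)c1ccccc1OC(=O)COc1cc(O)c2c(=O)cc(-c3ccccc3)oc2c1` gives 28500 nM in a functional assay on cells (T-cell, Mus musculus, strain BALB/c) for inhibition, read by MTT assay, with a stated time of 72 h (on this read-out higher numbers stand for weaker inhibition and lower numbers for stronger inhibition), the lowest of the three numbers measured. Its nearest neighbour is compound 2 `COC(=O)c1cccc(Cl)c1OC(=O)COc1cc(O)c2c(=O)cc(-c3ccccc3)oc2c1`, which in this assay gives 38700 nM, and the furthest is compound 1 `COC(=O)c1c(Br)cc(Br)cc1OC(=O)COc1cc(O)c2c(=O)cc(-c3ccccc3)oc2c1`, which in this assay gives 45700 nM; both gaps lie within the scatter, so no order among the three can be read from them.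

Compound 4 `COC(=O)c1ccc(Br)cc1OC(=O)COc1cc(O)c2c(=O)cc(-c3ccccc3)oc2c1` differs from compound 3 by one change: bromo in place of hydrogen on an aromatic carbon.

For the measured compounds named here, the one measured step that bears on this is a 1.4-fold lower number from compound 2 to compound 3 (0.13 log units; within the scatter), the removal of a halogen from the same ring in the opposite direction, and it stayed within the scatter. Compound 1, which carries two bromo groups on that ring, also sits within the scatter of compound 3. Neither observation points to a shift beyond the scatter when a single bromo enters, so the expectation for compound 4 in this assay is a number close to that of compound 3, if anything slightly higher, as expressed by the expected step of a 1.2-fold higher number from compound 3 to compound 4 (0.09 log units; within the scatter). Compound 4 is therefore estimated at 35000 nM, with a range from 18000 nM to 70000 nM.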

Compound 4, half-maximal inhibitory concentration: 17600 nM
Compound 4: middle estimate off by 2.0-fold (0.30 log units), on the high side, outside the stated range (below it).
By their numbers in this assay, from the lowest: compounds 4, 3, 2 and 1 (each within the scatter of the next, the first and the last beyond it).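

In this assay a single bromo at this place, meta to a large group and para to a methoxycarbonyl group, brings no change that can be read, with a 1.6-fold lower number from compound 3 to compound 4 (0.21 log units; within the scatter), so compound 3 and compound 4 cannot be ordered. Compound 4 nevertheless provides the first separations beyond the scatter among the compounds shown, modest ones: a 2.2-fold lower number from compound 2 to compound 4 (0.34 log units; beyond the scatter), between two compounds that each carry one halogen on that ring, and a 2.6-fold lower number from compound 1 to compound 4 (0.41 log units; beyond the scatter), where one of the two bromo groups is replaced by hydrogen. Bromo at this place is therefore tolerated in this series, and the second bromo of compound 1, rather than the one retained in compound 4, accounts for that separation, although compound 2 differs from compound 4 in both the halogen and its place, so those two factors cannot be told apart.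

From the compounds shown here alone, it remains open whether an amine, a carboxylic acid, a methoxy group or a longer chain at this place would shift the number beyond the scatter from compound 3. Nothing available gives a reason for the separations seen.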